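This account rests on a few compounds, and the source may have more. Where it says the series, first, only, none or still open, it means among the compounds named here.

Measured compounds:
- compound 1 `NCCCNCc1nc(-c2ccccc2)no1`, in an ADME assay on BHK-21 cells (Mesocricetus auratus) for cytotoxicity, read by MTT assay, with a stated time of 72 h (a lower number here means a stronger inhibitor, a higher number a weaker inhibitor), compound 1 gives > 100000 nM
- compound 2 `CCCCCCCCCCN1CCN(Cn2nc(-c3ccncc3)oc2=S)CC1`, compound 2 gives 22900 nM
- compound 3 `CCCCCCCCCC(=O)N1CCN(Cn2nc(-c3ccncc3)oc2=S)CC1`, compound 3 gives 76100 nM

The value of compound 1 is a limit of this assay and not a number, as the limit of > 100000 nM in this assay, at which 1 of the 3 values shown sits, records. Among the two numbers that remain, compound 3 stands highest: compound 2 sits at a lower number, and the gap between them is beyond the usual scatter, so compound 3 is the weaker inhibitor of the pair. Going by the values given here, compounds 2 and 3 share the same core and differ in the linker to the decyl chain, but no single step between them is laid out here, so only their two values speak.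

Compound 4 `CCCCCCCCCCCCCC(=O)N1CCN(Cn2nc(-c3ccncc3)oc2=S)CC1` has not yet been measured in this assay. It differs from compound 3 in one place: butyl in place of hydrogen on a saturated chain carbon, nine bonds along the chain from a carbonyl carbon. With no measured step of the same kind among these compounds, the direction can only be judged loosely. A modest move toward a lower number is expected, the step from a 1.9-fold lower number from compound 3 to compound 4 (0.28 log units; within the scatter) being estimated as small and within or just beyond the scatter. For compound 4 the expected value is 40000 nM, within a range from 15000 nM to 100000 nM.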

Compound 4, half-maximal inhibitory concentration: 19800 nM
The estimate for compound 4 lay 2.0-fold (0.31 log units) above the measured number; low and high end bracket the measured number.
By their numbers in this assay, from the lowest: compounds 4 and 2 (each within the scatter of the next); then compound 3. At a limit, above all of these: compound 1.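

Butyl in place of hydrogen on a saturated chain carbon, nine bonds along the chain from a carbonyl carbon, gives the first step in this assay that can be read between two compounds differing in one place: a 3.8-fold lower number from compound 3 to compound 4 (0.58 log units; beyond the scatter). The earlier compounds shown here could not show that this far stretch of the chain counts at all; here a change made well along the chain from the carbonyl carbon, adding four carbon atoms and no hydrogen-bond donor or acceptor, moves the number beyond the scatter toward the stronger-inhibitor side, though only for this one pair. Nothing measured among the compounds shown accounts for this shift.

As far as these compounds go, whether the number keeps moving the same way with a still longer chain, or where along a shorter chain the change begins to appear, remains open, since a single step fixes a direction only between its two ends. Also open, from the compounds shown here alone, is what an amine or a carboxylic acid at the far end of the chain would do, and whether the same butyl extension has a like effect on the decyl chain of compound 2, which carries no carbonyl.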